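From Fluoro to Chloro in an Antiproliferative Series

This account rests on a few compounds, and the source may have more. Where it says the series, first, only, none or still open, it means among the compounds named here.

Of the compounds shown here, three sharing one core have so far been measured in a functional assay on MKN-45 cells (Homo sapiens) for antiproliferative activity, read by MTT assay, with a stated time of 72 h (on this read-out higher numbers stand for weaker inhibition and lower numbers for stronger inhibition), and can frame the next result. Compound 1 (`COc1cc(CCc2ccncc2)cc(OC)c1O`) gives 3810 nM in this test. Compound 2 (`COc1cc(CCc2ccc(Cl)c(Cl)c2)cc(OC)c1O`) gives 20600 nM in the same test. Compound 3 (`COc1cc(CCc2ccc(F)cc2)cc(OC)c1O`) gives 10700 nM there. Compound 3 thus stands close to compound 2, the two lying within the scatter of each other, while compound 1 shows a lower number, and so stronger inhibition, by a margin beyond the scatter.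

Compound 4 (`COc1cc(CCc2ccc(Cl)cc2)cc(OC)c1O`) has not yet been measured. It differs from compound 3 by a single exchange (chloro in place of fluoro on an aromatic carbon): chloro in place of fluoro on an aromatic carbon, para to a large group. For the measured compounds named here, no measured pair shows this exchange alone, so there is no direct step to lean on. The nearest guide is compound 2, which also carries chloro and gives 20600 nM in this assay without leaving the scatter around compound 3. A change beyond the scatter is therefore not expected, and any drift would be toward a slightly higher number. The estimate means an expected step of a 1.2-fold higher number from compound 3 to compound 4 (0.08 log units; within the scatter) that stays within the scatter. For compound 4 the expected value is 13000 nM with an estimated range from 6500 nM to 25000 nM once it is measured.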

Compound 4, half-maximal inhibitory concentration: > 25000 nM
Compound 4: no number, only a limit; the forecaster's own chance of this, stated with the estimate: 3%; middle value at least 1.9-fold (0.28 log units) away from the limit.
By their numbers in this assay, from the lowest: compound 1; then compounds 3 and 2 (each within the scatter of the next). At a limit, above all of these: compound 4.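

For the compounds shown here, the exchange of chloro for fluoro on an aromatic carbon, para to a large group, had no direct measure among the earlier compounds, and here it gives an at least 2.3-fold higher number from compound 3 to compound 4 (0.36 log units; beyond the scatter), a shift toward weaker inhibition from this single change. In this assay, as far as these compounds go, compound 4 gives > 25000 nM as a limit of the assay and not a number, so the true size of the step remains unknown and only its minimum is given: the limit of > 25000 nM in this assay, at which 1 of the 4 values shown sits. Hydrogen in place of chloro on an aromatic carbon gives an at least 1.2-fold higher number from compound 2 to compound 4 (0.08 log units; that floor lies within the scatter), so the data do not settle whether that exchange moves the read-out at all, and what can be said is only that the limit for compound 4 stands beyond the value of compound 2.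

From the compounds shown here alone, how far the true value of compound 4 lies beyond its limit stays open. Also open, going by these compounds, is whether an amine, a methoxy group or a carboxylic acid, placed para to a large group on the same aromatic ring, would give a lower number than fluoro or chloro in this assay.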